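A few compounds are considered here, and "the series" means these few. Any claim that something is new, unique, unknown or untested is made for them only; others in the source may bear on it.

Three compounds have been measured for inhibition of cell growth:

Compound 1, `FC(F)(F)c1ccc(-c2noc(-c3sccc3Cl)n2)nc1`: in a functional assay on DLD-1 cells (Homo sapiens) for inhibition, with a stated time of 48 h, at 37 degrees C (a higher number here means a weaker inhibitor of growth, a lower number a stronger inhibitor of growth), compound 1 gives 930 nM.
Compound 2, `Clc1ccc(-c2noc(-c3sccc3Cl)n2)nc1`: in this assay compound 2 gives 800 nM.
Compound 3, `Clc1ccc(-c2noc(-c3occc3Br)n2)cc1`: in this assay compound 3 gives 510 nM.

Compound 4, `FC(F)(F)c1ccc(-c2noc(-c3occc3Br)n2)cc1`, has not yet been measured. It differs from compound 3 in one place: trifluoromethyl in place of chloro on an aromatic carbon. The same kind of change has already been made once, between compound 2 and compound 1: trifluoromethyl in place of chloro on an aromatic carbon. There the step was a 1.2-fold higher number from compound 2 to compound 1 (0.07 log units; within the scatter). The two changes are alike in kind but not the same, since in compound 1 the group sits on a six-membered aromatic ring with 1 nitrogen, two atoms from the ring nitrogen, whereas in compound 4 it sits on a six-membered aromatic ring of carbon only, in both cases para to a large group. How the core of compound 3 differs from the core of compound 2 is not broken down here.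

For compound 4 a step of similar size is expected, a 1.2-fold higher number from compound 3 to compound 4 (0.07 log units; within the scatter), because the earlier step of a 1.2-fold higher number from compound 2 to compound 1 (0.07 log units; within the scatter) stayed within the scatter. Compound 4 is therefore estimated at 600 nM, expected to fall between 300 nM and 1200 nM.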

Compound 4, concentration for 50% growth inhibition: 130 nM
Compound 4: middle estimate off by 4.6-fold (0.66 log units), on the high side; measured number below the stated range.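

In this assay, trifluoromethyl in place of chloro on the core of compound 3 gives a 3.9-fold lower number from compound 3 to compound 4 (0.59 log units; beyond the scatter), so on this core the change goes with a stronger inhibitor of growth. The same change does not carry over at the same size from one core to the other: the same change on two cores in this assay, a 1.2-fold higher number (0.07 log units; within the scatter) from compound 2 to compound 1 and a 3.9-fold lower number (0.59 log units; beyond the scatter) from compound 3 to compound 4, 4.6-fold (0.66 log units) apart, beyond the scatter of two such steps. The two cores differ in more than one place, so these two pairs do not show which difference sets the size of the step, nor what the change would do on a third core.

The compounds shown leave open how other groups in the same spot, such as a nitrile, a methoxy group or an amine, would compare with chloro and trifluoromethyl on either core. Going by these compounds alone, they also leave open whether the larger step survives when only one part of the core of compound 3 is altered, for instance with chloro in place of its bromo group.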